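The compounds below may be only part of what the source reports. "The series", "measured", "known", "first", "only" and "open" are said of these compounds alone.

Working notes on the series.

All compounds are compared in an assay on isolated protein for inhibition of alpha-ketoglutarate-dependent dioxygenase alkB homolog 3 (Homo sapiens), read by polymerase chain reaction, with a stated time of 1 h; a higher number here means a weaker inhibitor, a lower number a stronger inhibitor. Compound 1 `Cc1ccc2[nH]c(-n3[nH]c(C)c(Cc4ccccc4)c3=O)nc2c1` gives 670 nM in this assay. Compound 3 `Cc1ccc2[nH]c(-n3[nH]c(C)c(C)c3=O)nc2c1` gives 2600 nM in this assay. The move between them is hydrogen in place of phenyl on a saturated chain carbon bound to an aromatic carbon and it costs a 3.9-fold higher number from compound 1 to compound 3 (0.59 log units; beyond the scatter), so removing the phenyl from that position is a clear loss within this pair.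

Compound 2 `O=c1c(Cc2ccccc2)c(-c2ccccc2)[nH]n1-c1nc2ccccc2[nH]1` sits at a limit of this assay, > 10000 nM, and no number is available for it. That value is one of those at the limit of > 10000 nM in this assay, at which 1 of the 3 values shown sits. How the core of compound 2 differs from the core of compound 1 is not broken down here; the two differ in more than one place.

Compound 4 `Cc1c(-c2ccccc2)[nH]n(-c2nc3ccccc3[nH]2)c1=O` is not yet measured. Among the compounds with values here, it differs from compound 2 by hydrogen in place of phenyl on a saturated chain carbon bound to an aromatic carbon, which is the same change, at the same place, as the one made from compound 1 to compound 3.

Expectation for compound 4 in this assay: the step from compound 2 to compound 4 is estimated at a step that the limit leaves unreadable from compound 2 to compound 4, set beside the measured 3.9-fold higher number from compound 1 to compound 3 (0.59 log units; beyond the scatter) in the same direction, on the ground that the only measured instance of this change weakened the compound. Because compound 2 already stands at > 10000 nM, compound 4 is expected to stay at the limit as well. The estimated value for compound 4 in this assay is 30000 nM, with a range from 10000 nM to 100000 nM.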

Compound 4, half-maximal inhibitory concentration: > 10000 nM
Compound 4: a limit, no number; the forecaster's own chance of this, stated with the estimate: 90%; the middle value lies beyond the limit too.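

In this assay compound 4 gives > 10000 nM, which is a limit and not a number. Compound 2 sits at the same limit, so no step between compound 2 and compound 4 can be read: the limit of > 10000 nM in this assay, at which 2 of the 4 values shown sit.

The compounds shown leave open whether the change from benzyl to methyl weakens binding on the core of compound 2 as it does on the core of compound 1.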